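The source may hold more compounds than are shown below. What is called first, only, known or untested is meant among the compounds shown, and "the series" means these compounds.

The measured compounds:

Compound 1 `ClCc1ccc(Cn2cnc3c(Cl)ncnc32)cc1` gives 3630 nM.
Compound 2 `Nc1nc(Cl)c2ncn(Cc3ccc(CCl)cc3)c2n1` gives 6760 nM.
Compound 3 `ClCc1ccccc1Cn1cnc2c(Cl)ncnc21` gives 5370 nM.

All three were tested in a functional assay on SNB-19 cells (Homo sapiens) for cytotoxicity, read by sulforhodamine B assay, with a stated time of 48 h; on this read-out higher numbers stand for weaker inhibition of growth and lower numbers for stronger inhibition of growth. Compound 1 and compound 2 share one core and differ in a single place: amino in place of hydrogen on an aromatic carbon. That change brought a 1.9-fold higher number from compound 1 to compound 2 (0.27 log units; within the scatter), so the two numbers sit close together and no order can be read from them.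

Compound 3 is built from the same atoms as compound 1, joined differently; the difference between the two cores is not broken down here. Compound 3 and compound 2 give numbers within the scatter of each other, as do compound 3 and compound 1.

Compound 4 `Nc1nc(Cl)c2ncn(Cc3ccccc3CCl)c2n1` has not yet been tested. It stands to compound 3 as compound 2 stands to compound 1: amino in place of hydrogen on an aromatic carbon. The surroundings of the place are described in the same words for both pairs, so this is the same change made a second time on a different core.

For the measured compounds named here, the only guide is the step seen in the first pair. The expectation is that compound 4 will show a 1.8-fold higher number from compound 3 to compound 4 (0.25 log units; within the scatter), because the same change gave a 1.9-fold higher number from compound 1 to compound 2 (0.27 log units; within the scatter). Going by the values given here, with only one earlier example, the range is kept wide. Compound 4 is therefore estimated at 9500 nM, expected between 4000 nM and 22000 nM.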

Compound 4, concentration for 50% growth inhibition: 6030 nM
Beside the measured number, compound 4's estimate is 1.6-fold (0.20 log units) above it, and the stated range covers the measured number.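

In this assay, putting amino in place of hydrogen on an aromatic carbon gave a 1.1-fold higher number from compound 3 to compound 4 (0.05 log units; within the scatter), so compound 3 and compound 4 cannot be placed in any order. Set beside the first example of this change, the new step shows no difference between the two cores that stands clear of ordinary measurement noise: the same change on two cores in this assay, a 1.9-fold higher number (0.27 log units; within the scatter) from compound 1 to compound 2 and a 1.1-fold higher number (0.05 log units; within the scatter) from compound 3 to compound 4, 1.7-fold (0.22 log units) apart, within the scatter of two such steps. This shows that, in both pairs, the change left the growth-inhibition number within the scatter, and that the two cores gave matching results for this one change; it does not show that amino has no effect at all, since a small real effect could be hidden in the scatter, and two pairs are too few to establish a rule for the wider series.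

The compounds shown leave open whether a different group on that same aromatic carbon, such as methylamino, a longer alkylamino chain, hydroxyl or methoxy, would move the number clearly beyond the scatter. They also leave open whether a change elsewhere in these molecules, such as a methoxy group in place of the chloro group, would carry from one core to the other in the same way.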